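Swapping a para chloro for methyl on a dithiocarbamate

The source may hold more compounds than are shown below. What is called first, only, known or untested is meant among the compounds shown, and "the series" means these compounds.

Three compounds share one core, a piperazine dithiocarbamate tied through a triazole to a substituted benzyl group. Compound 1 `Fc1ccccc1Cn1cc(CSC(=S)N2CCNCC2)nn1` was tested in a functional assay on MGC-803 cells (Homo sapiens) for inhibition, read by MTT assay, with a stated time of 72 h (on this read-out higher numbers stand for weaker inhibition and lower numbers for stronger inhibition), and gives 19400 nM. Compound 2 `S=C(SCc1cn(Cc2ccc(Cl)cc2)nn1)N1CCNCC1` is recorded in this assay as "not determined" (no result reported), so nothing places it on the scale. Compound 3 `Cc1ccc(Cn2cc(CSC(=S)N3CCNCC3)nn2)cc1` differs from compound 2 by methyl in place of chloro on an aromatic carbon. Going by the values given here, no measured step is available for this kind of swap, so no change beyond the usual scatter is expected. Compound 3 is estimated at 20000 nM, within 6000 nM to 60000 nM.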

Compound 3, half-maximal inhibitory concentration: 64300 nM
For compound 3 the middle estimate is 3.2-fold (0.51 log units) below the measured one, outside the stated range (above it).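

In this assay the aryl group on this chain matters: 4-methylphenyl in place of 2-fluorophenyl gives a 3.3-fold higher number from compound 1 to compound 3 (0.52 log units; beyond the scatter), a modest weakening of inhibition that goes beyond the scatter. The chloro to methyl swap itself cannot be read, since compound 2 has no number. Nothing measured here accounts for the weakening.

Compound 1 and compound 3 differ in both the substituent and where it sits, so the two effects remain unseparated. On these data alone, how an amine or a carboxylic acid would read in place of the methyl of compound 3 also stays open.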